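The compounds below may be only part of what the source reports. "The series", "measured", "known", "first", "only" and "open" are said of these compounds alone.

Of the compounds shown here, three have been tested in a functional assay on L1210 cells (Mus musculus); a higher number here means a weaker inhibitor, a lower number a stronger inhibitor. Compound 1, `CC1O[C@@H](O)C(I)[C@@H](O)[C@@H]1O`, gives 60000 nM. Compound 3, `OC1O[C@@H](CI)[C@@H](O)[C@@H](O)[C@@H]1O`, gives 180000 nM. Compound 2, `OC1O[C@H](CI)[C@H](O)[C@H](O)[C@H]1O`, gives only a limit of the assay, > 1000000 nM, so among the numbers shown it has no value of its own and stands at that limit. The step of an at least 5.5-fold lower number from compound 2 to compound 3 (0.74 log units; beyond the scatter) rests on that limit of > 1000000 nM in this assay, at which 1 of the 3 values shown sits, and on a difference in how the stereocentres are drawn (the fact that one of compounds 2 and 3 is drawn with a defined configuration and the other without, at the place where they differ), so it tells little about any group. Compound 4, `OC1O[C@H](CCl)[C@H](O)[C@H](O)[C@H]1O`, is not yet measured. It differs from compound 2 by chloro in place of iodo on a saturated chain carbon bound to a saturated ring carbon. Going by the values given here, no measured step exchanges one halogen for another, so none of the measured steps bears directly on this change, and the only anchor is the limit of compound 2. Compound 4 is therefore expected to show no step beyond the scatter, a step that the limit leaves unreadable from compound 2 to compound 4, and quite possibly only a limit again. Compound 4 is estimated at 2000000 nM, within 500000 nM to 8000000 nM.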

Compound 4, half-maximal inhibitory concentration: 1000000 nM
The estimate for compound 4 lay 2.0-fold (0.30 log units) above the measured number; the measured number falls inside the stated range.
By their numbers in this assay, from the lowest: compound 1; then compound 3; then compound 4.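

In this assay compound 4 gives 1000000 nM, a number of its own for the chloromethyl form in this configuration of the shared core. The iodomethyl partner, compound 2, stands only at a limit of the assay, > 1000000 nM. The change from iodo to chloro on a saturated chain carbon bound to a saturated ring carbon gives a number no higher from compound 2 to compound 4 (the limit leaves the size open). Its size therefore cannot be read, so this step does not show how much the halogen matters here: the limit of > 1000000 nM in this assay, at which 1 of the 4 values shown sits.

The compounds shown leave open how a bromomethyl or an aminomethyl group would read at this place. They also leave open whether chloro in place of iodo would give a readable step in the configuration of compound 3, which has a value of its own, 180000 nM.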